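The compounds below may be only part of what the source reports. "The series", "measured", "known", "first", "only" and "open" are said of these compounds alone.

Three compounds share one core and differ only at the end of the chain. Compound 1 `COc1cc2c(Nc3ccc(C#N)cc3)ncnc2cc1OCCCN(C)Cc1ccccc1` reaches only the limit of a functional assay on HepG2 cells (Homo sapiens) for antiproliferative activity, read by MTT assay, with a stated time of 72 h (a lower number here means a stronger inhibitor, a higher number a weaker inhibitor), giving > 100000 nM. In this assay compound 2 `COc1cc2c(Nc3ccc(C#N)cc3)ncnc2cc1OCCCN1CCC(C)CC1` gives 32100 nM, and compound 3 `COc1cc2c(Nc3ccc(C#N)cc3)ncnc2cc1OCCCN1CCC(c2ccccc2)CC1` gives 4610 nM, the lowest of the two numbers. The step of a 7.0-fold lower number from compound 2 to compound 3 (0.84 log units; beyond the scatter) is modest, while an at least 21-fold lower number from compound 1 to compound 3 (1.33 log units; beyond the scatter) is large. Compound 4 `COc1cc2c(Nc3ccc(C#N)cc3)ncnc2cc1OCCCN1CCN(c2ccncc2)CC1` carries 4-(pyridin-4-yl)piperazin-1-yl in place of 4-phenylpiperidin-1-yl on a saturated chain carbon, three bonds along the chain from an oxygen on an aromatic ring. The step of a 7.0-fold lower number from compound 2 to compound 3 (0.84 log units; beyond the scatter) bears most directly on this place, since it too exchanged groups there. Compound 4 keeps a six-membered aromatic ring at this place. The step of a 1.7-fold higher number from compound 3 to compound 4 (0.24 log units; within the scatter) is expected to be small, within the scatter or a little upward. Compound 4 is therefore estimated at 8000 nM, between 2500 nM and 25000 nM.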

Compound 4, half-maximal inhibitory concentration: 12600 nM
The estimate for compound 4 lay 1.6-fold (0.20 log units) below the measured number; the measured number falls inside the stated range.
By their numbers in this assay, from the lowest: compound 3; then compound 4; then compound 2. At a limit, above all of these: compound 1.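

In this assay, exchanging one group for another of equal heavy-atom count still moves the result at this place, with a 2.7-fold higher number from compound 3 to compound 4 (0.44 log units; beyond the scatter). The pyridine-bearing group nonetheless keeps an advantage over the small 4-methylpiperidin-1-yl group, with a 2.5-fold lower number from compound 2 to compound 4 (0.41 log units; beyond the scatter). The comparison with compound 1, an at least 7.9-fold lower number from compound 1 to compound 4 (0.89 log units; beyond the scatter), rests on a limit: the limit of > 100000 nM in this assay, at which 1 of the 4 values shown sits.

As far as these compounds go, the ring nitrogens of the piperazine and the pyridine changed together, so their separate contributions remain open. A 4-phenylpiperazin-1-yl or 4-(pyridin-4-yl)piperidin-1-yl group would separate them.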